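The source may report more compounds than this note shows. Statements on the series, on what has been measured and on what is new or still open speak of the compounds shown alone.

Compound 2 `COc1ccc(-c2cn3ccnc3c(-c3ccc4ncn(C5CCCCC5)c4c3)n2)cc1` stands highest of the two numbers in a functional assay on SK-OV-3 cells (Homo sapiens) for inhibition, read by sulforhodamine B assay, with a stated time of 48 h, tested at 10 uM (a higher number here means more inhibition at the concentration tested (going by the name of the read-out), a lower number less inhibition), where compound 2 gives 74.3%. Compound 1 `c1ccc(-c2cn3ccnc3c(-c3ccc4ncn(C5CCCCC5)c4c3)n2)cc1` gives 7.52% in this assay, and the step of a number 66.8 percentage points higher from compound 1 to compound 2 (beyond the scatter) is the only measured one in the series. Compound 3 `O=Cc1ccc(-c2cn3ccnc3c(-c3ccc4ncn(C5CCCCC5)c4c3)n2)cc1` is reached from compound 2 by formyl in place of methoxy on an aromatic carbon. Among the measured compounds shown here, only the step from compound 1 to compound 2 bears on this change; it shows that the group in this place moves the read-out strongly, but whether formyl behaves more like methoxy or like hydrogen cannot be read from two compounds. For compound 3 the expected step in this assay is a number 29.3 percentage points lower from compound 2 to compound 3 (beyond the scatter), a decrease with wide uncertainty. Compound 3 is estimated at 45%, between 10% and 80%.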

Compound 3, a percentage reported as inhibition, at one concentration (the size of the read-out at that concentration, not a potency): 5.11%
Compound 3: middle estimate off by 39.9 percentage points, on the high side, and the stated range ends above it.
By their numbers in this assay, from the lowest: compounds 3 and 1 (each within the scatter of the next); then compound 2.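

In this assay, formyl does not keep the gain seen with methoxy on this aromatic carbon, para to a large group (a number 69.2 percentage points lower from compound 2 to compound 3 (beyond the scatter)). Set against hydrogen, formyl shows no change beyond the scatter (a number 2.4 percentage points lower from compound 1 to compound 3 (within the scatter)), so of the three groups only methoxy lifts the read-out. Nothing measured here accounts for the gap between methoxy and formyl. As far as these compounds go, whether a hydroxyl, an amine or a longer chain such as ethoxy would hold the read-out of methoxy stays open. From the compounds shown here alone, whether a carboxylic acid would sit with formyl and hydrogen also stays open.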